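The source may hold more compounds than are shown below. What is called first, only, known or untested is meant among the compounds shown, and "the series" means these compounds.

Three compounds built on one shared core have been compared in a functional assay on A549 cells (Homo sapiens) for inhibition, read by MTT assay, with a stated time of 72 h; a higher number here means a weaker inhibitor, a lower number a stronger inhibitor. Compound 1 `CN(C(=O)NC(=O)c1cccc(C(F)(F)F)c1)c1nc(C(F)(F)F)c(C(=O)N/N=C/c2cccc(C(F)(F)F)c2)s1` gives 8.16 ug/mL, compound 2 `CN(C(=O)NC(=O)c1ccc([N+](=O)[O-])cc1)c1nc(C(F)(F)F)c(C(=O)N/N=C/c2cccc(C(F)(F)F)c2)s1` gives 5.42 ug/mL and compound 3 `CN(C(=O)NC(=O)c1ccccc1)c1nc(C(F)(F)F)c(C(=O)N/N=C/c2cccc([N+](=O)[O-])c2)s1` gives 20.7 ug/mL. Compound 2 has the lowest of the three numbers, close to compound 1 and well apart from compound 3. Compound 4 `CN(C(=O)NC(=O)c1ccc([N+](=O)[O-])cc1)c1nc(C(F)(F)F)c(C(=O)N/N=C/c2ccc([N+](=O)[O-])cc2)s1` differs from compound 2 in one place: 4-nitrophenyl in place of 3-(trifluoromethyl)phenyl on a carbon with a double bond to nitrogen. Within the data shown here, the only measured step of the same kind, a 1.5-fold lower number from compound 1 to compound 2 (0.18 log units; within the scatter), made this swap on a carbonyl carbon and stayed within the scatter. Among the measured compounds shown here, compound 3 gives a higher number than either compound 1 or compound 2, but it differs from each in two places, so it offers no single step. The expected step is therefore a 1.6-fold higher number from compound 2 to compound 4 (0.20 log units; within the scatter), small and if anything toward a higher number. Compound 4 is estimated at 8.5 ug/mL, within 4 ug/mL to 18 ug/mL.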

Compound 4, half-maximal inhibitory concentration: 8.98 ug/mL
Estimate against measurement, compound 4: 1.1-fold (0.02 log units) below; low and high end bracket the measured number.
By their numbers in this assay, from the lowest: compounds 2, 1 and 4 (each within the scatter of the next); then compound 3.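

At the carbon with a double bond to nitrogen, 4-nitrophenyl in place of 3-(trifluoromethyl)phenyl gives a 1.7-fold higher number from compound 2 to compound 4 (0.22 log units; within the scatter) in this assay. Among these compounds, this place therefore joins the carbonyl carbon, where the same swap gave a 1.5-fold lower number from compound 1 to compound 2 (0.18 log units; within the scatter), in showing no step beyond the scatter, something the earlier compounds could not show for this place. Nothing measured here gives a reason for this result.

Still open, going by these compounds, is whether a phenyl ring carrying an amine or a carboxylic acid would behave the same way at this place. A longer chain instead of the ring is equally untested by the compounds shown.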